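Removing a Methyl from a Chemokine Receptor Binder

This account rests on a few compounds, and the source may have more. Where it says the series, first, only, none or still open, it means among the compounds named here.

Compound 1 `O=C(NCc1ccc(CNS(=O)(=O)c2ccccc2)cc1)c1ccc([N+](=O)[O-])cc1`: 100 nM
Compound 2 `Cc1ccc(S(=O)(=O)NCc2ccc(CNC(=O)c3ccncc3)cc2)cc1`: 10 nM

Of the compounds shown here, two have been measured in an assay on MDA-MB-231 cells for binding affinity to C-X-C chemokine receptor type 4 (Homo sapiens), read by immunofluorescence and microscopy, with stated times of 10 min and 30 min; a higher number here means that more compound is needed for the effect, a lower number that less compound is needed. Compound 2 gives the lower of the two numbers, with 10 nM, and its nearest neighbour is compound 1, whose value of 100 nM lies beyond the usual scatter. Compound 3 `O=C(NCc1ccc(CNS(=O)(=O)c2ccccc2)cc1)c1ccncc1` has not yet been measured. It is made from compound 2 by one change, (hydrogen in place of methyl on an aromatic carbon); cut one bond further out, the same difference reads 4-methylphenyl to phenyl. Among the measured compounds shown here, no measured pair shows this change on its own, so its size can only be expected, not read off. The amide part that sets compound 2 apart from compound 1 is kept unchanged in compound 3, and the change itself is small in what it counts, so the step in this assay from compound 2 to compound 3 is expected to stay within the scatter, a 1.5-fold higher number from compound 2 to compound 3 (0.18 log units; within the scatter). Compound 3 is therefore estimated at 15 nM, in a range from 5 nM to 50 nM.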

Compound 3, effective concentration (reported as EC, without a stated level of effect): 10 nM
Beside the measured number, compound 3's estimate is 1.5-fold (0.18 log units) above it, and the stated range covers the measured number.
By their numbers in this assay, from the lowest: compounds 2 and 3 (each within the scatter of the next); then compound 1.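

In this assay the step reads no change at the digits printed from compound 2 to compound 3 (within the scatter) when hydrogen takes the place of methyl on an aromatic carbon, para to a large group, so in this pair the methyl makes no difference that the assay can detect. Among the compounds shown here, the new compound also gives the first pair that differs only in the amide part, with a 10-fold lower number from compound 1 to compound 3 (1.00 log units; beyond the scatter) for pyridin-4-yl in place of 4-nitrophenyl on a carbonyl carbon, whereas the two earlier compounds differ in two places and could not separate the changes. Nothing measured here explains either step.

As far as these compounds go, whether a methoxy group, a chlorine atom or a longer chain at this place would also leave the number where it is remains open. So does what a piperidine ring on the carbonyl carbon would do.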